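Aryl swap at the ring carbon: furan-2-yl analogue

The compounds below may be only part of what the source reports. "The series", "measured", "known", "first", "only" and "open" are said of these compounds alone.

Compound 2 `CCOC(=O)C12C(=O)OCC=C1COC2c1ccc(Cl)cc1` carries a 4-chlorophenyl on the saturated ring carbon of the shared core. In a functional assay on HeLa cells (Homo sapiens) for cytotoxicity, read by MTT assay (a higher number here means a weaker inhibitor, a lower number a stronger inhibitor), compound 2 gives 118000 nM, the highest of the two numbers in hand. For the measured compounds named here, its only neighbour is compound 1 `CCOC(=O)C12C(=O)OCC=C1COC2c1ccccc1F`, which in this assay gives 22100 nM; the step of a 5.3-fold higher number from compound 1 to compound 2 (0.73 log units; beyond the scatter) is the sole measured comparison.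

Compound 3 `CCOC(=O)C12C(=O)OCC=C1COC2c1ccco1` is the next member: furan-2-yl in place of 4-chlorophenyl on a saturated ring carbon. Going by the values given here, the one step that bears on this change is the aryl exchange from compound 1 to compound 2, a modest shift beyond the scatter, which shows that the group at this carbon moves the number, but in only one direction so far and with a different pair of groups. A furan-2-yl in place of 4-chlorophenyl is therefore expected to give a moderate step back toward the lower number, a 2.4-fold lower number from compound 2 to compound 3 (0.37 log units; beyond the scatter), though the direction is poorly anchored. The estimate for compound 3 in this assay is 50000 nM, within a range from 15000 nM to 160000 nM.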

Compound 3, half-maximal inhibitory concentration: 28300 nM
Estimate against measurement, compound 3: 1.8-fold (0.25 log units) above; low and high end bracket the measured number.
By their numbers in this assay, from the lowest: compounds 1 and 3 (each within the scatter of the next); then compound 2.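

In this assay, the group on this saturated ring carbon now moves the number in both directions: a 4.2-fold lower number from compound 2 to compound 3 (0.62 log units; beyond the scatter), which takes back most of the rise seen with the 4-chlorophenyl group. The furan-2-yl and 2-fluorophenyl groups cannot be told apart, with a 1.3-fold higher number from compound 1 to compound 3 (0.11 log units; within the scatter), so among these three compounds neither a change from a six-membered to a five-membered aromatic ring nor the presence of a ring oxygen in the aromatic group separates the numbers, and only compound 2 stands apart. Nothing available explains why the 4-chlorophenyl group stands apart from the other two groups.

The 4-chlorophenyl and 2-fluorophenyl groups differ in both the halogen and where it stands on the ring, so these compounds cannot show which of the two accounts for the step to compound 2, a question that 2-chlorophenyl and 4-fluorophenyl analogues would address. Also open, as far as these compounds go, is how this carbon would respond to a group without an aromatic ring, such as cyclohexyl, or to an aryl group carrying an amine or a carboxylic acid.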